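The source may hold more compounds than are shown below. What is called first, only, known or untested is meant among the compounds shown, and "the series" means these compounds.

Measured in a functional assay on KB cells (Homo sapiens) for antiproliferative activity, read by MTT assay, with a stated time of 72 h; a lower number here means a stronger inhibitor, a higher number a weaker inhibitor:
- Compound 1 `COc1ccc(-c2ssc(=S)c2-c2cc(OC)c(OC)c(OC)c2)cc1`: 4910 nM
- Compound 2 `COc1ccc(-c2c(-c3cc(OC)c(OC)c(OC)c3)ssc2=S)cc1`: 1140 nM
- Compound 3 `COc1ccc(-c2c(-c3cc(OC)c(OC)c(OC)c3)ssc2=S)cc1[N+](=O)[O-]`: 38200 nM

At 38200 nM, compound 3 has the highest number of the three, which makes it the weakest inhibitor in this small set. The next structure, compound 4 `COc1ccc(-c2c(-c3cc(OC)c(OC)c(OC)c3)ssc2=S)cc1N`, carries amino in place of nitro on an aromatic carbon, ortho to a methoxy group: amino in place of nitro on an aromatic carbon.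

Going by the values given here, only one measured step touches this carbon: a 34-fold higher number from compound 2 to compound 3 (1.53 log units; beyond the scatter), a large change for nitro in place of hydrogen. Among the compounds with values here, compound 4 loses that nitro, but amino is not hydrogen, and no measured compound carries amino, so this step is only a rough guide. Even so, a return towards the level of compound 2 seems the likeliest outcome, since compound 2 gives 1140 nM without the nitro. A large step to a lower number is therefore expected in this assay, similar in size to the measured one, though how far it goes remains uncertain. The expected change is a 38-fold lower number from compound 3 to compound 4 (1.58 log units; beyond the scatter).

For compound 4 the estimated value is 1000 nM, with an expected range from 150 nM to 6000 nM.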

Compound 4, half-maximal inhibitory concentration: 2170 nM
The estimate for compound 4 lay 2.2-fold (0.34 log units) below the measured number; the measured number falls inside the stated range.
By their numbers in this assay, from the lowest: compounds 2 and 4 (each within the scatter of the next); then compound 1; then compound 3.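

In this assay, amino in place of nitro on this aromatic carbon gives an 18-fold lower number from compound 3 to compound 4 (1.25 log units; beyond the scatter), so the large penalty seen with nitro does not apply to every group placed here. Compared with the unsubstituted compound, amino in place of hydrogen gives a 1.9-fold higher number from compound 2 to compound 4 (0.28 log units; within the scatter), which lies within the scatter, so this assay cannot tell hydrogen and amino apart at this position, and of the three groups only nitro stands out. No measurement available here explains why nitro and amino differ so sharply at this carbon.

The compounds shown leave open how other groups on this carbon would behave, such as a hydroxyl, a fluorine or an acetylated amine, so it remains unknown whether nitro is a lone exception or one of several poorly tolerated groups. They also leave open whether nitro and amino would give a similar contrast on the core of compound 1, which carries neither group.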